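Tetrazole in place of the acid on the linear ketone chain

The source may hold more compounds than are shown below. What is called first, only, known or untested is meant among the compounds shown, and "the series" means these compounds.

Measured compounds:
compound 1, `CCCc1c(COc2ccc(C(=O)C(C)Cc3nnn[nH]3)cc2)ccc(C(C)=O)c1O`, 7.18 in a functional assay on ileum (Cavia porcellus) with cysteinyl leukotriene receptor (Homo sapiens) as the target; a higher number here means a more potent compound, by a factor of ten per unit of this negative logarithm, a lower number a less potent compound
compound 2, `CCCc1c(COc2ccc(C(=O)CCCC(=O)O)cc2)ccc(C(C)=O)c1O`, 6.81 in this assay

Of the two numbers in this assay, compound 2 stands lowest; its nearest neighbour is compound 1, and the step of a number 0.37 log units lower from compound 1 to compound 2 (beyond the scatter) lies beyond the usual scatter. Compound 3, `CCCc1c(COc2ccc(C(=O)CCCc3nnn[nH]3)cc2)ccc(C(C)=O)c1O`, is not yet measured. It differs from compound 2 by 1H-tetrazol-5-yl in place of carboxy on a saturated chain carbon, three bonds along the chain from a carbonyl carbon. Going by the values given here, only one measured step bears on this exchange: the step of a number 0.37 log units lower from compound 1 to compound 2 (beyond the scatter) replaced a tetrazole-bearing branched chain with the carboxy-bearing straight chain, so it mixes the acid-for-tetrazole swap with a change in chain shape and gives an imperfect guide. Reading it in reverse for compound 3, which keeps the straight chain of compound 2, a modest gain is expected, roughly the size of that earlier step, a number 0.29 log units higher from compound 2 to compound 3 (within the scatter). Compound 3 is therefore estimated at 7.1 in this assay, with a range from 6.6 to 7.6.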

Compound 3, negative logarithm of the antagonist equilibrium constant: 7.67
Beside the measured number, compound 3's estimate is 0.57 log units below it; measured number above the stated range.
By their numbers in this assay, from the lowest: compound 2; then compound 1; then compound 3.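

With the straight chain held fixed, 1H-tetrazol-5-yl in place of carboxy on a saturated chain carbon, three bonds along the chain from a carbonyl carbon, gives a number 0.86 log units higher from compound 2 to compound 3 (beyond the scatter) in this assay and so shows this exchange alone, apart from the change in chain shape that was mixed into the earlier step. With the tetrazole present on both sides, 3-(1H-tetrazol-5-yl)propyl in place of 1-((1H-tetrazol-5-yl)methyl)ethyl on a carbonyl carbon gives a number 0.49 log units higher from compound 1 to compound 3 (beyond the scatter) and shows that the shape of the chain also counts at this position, with the straight chain carrying the higher number in this pair. No measurement at hand accounts for either step.

On these data alone, what a carboxylic acid would give on the branched chain of compound 1 remains open, so the tetrazole exchange is known on the straight chain only. Also open, as far as these compounds go, is whether the order of the two groups holds on a shorter or a longer chain, and how a hydroxamic acid or an acyl sulfonamide would compare with the 3-(1H-tetrazol-5-yl)propyl chain of compound 3.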